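Swapping the five-membered ring on the thioether linker

The source may hold more compounds than are shown below. What is called first, only, known or untested is meant among the compounds shown, and "the series" means these compounds.

Two compounds share a core in which a sulfur, attached to a saturated chain carbon, carries a small aromatic ring. Compound 1 `Nc1nc(SCc2coc3ccccc3c2=O)n[nH]1` carries a 5-amino-1H-1,2,4-triazol-3-yl group there. In a functional assay on HeLa cells (Homo sapiens) for cytotoxicity, read by MTT assay, with a stated time of 72 h (on this read-out lower numbers stand for stronger inhibition and higher numbers for weaker inhibition), compound 1 gives only the limit > 25000 nM. Compound 2 `Cc1nnc(SCc2coc3ccccc3c2=O)o1` carries a 5-methyl-1,3,4-oxadiazol-2-yl group instead, and in this assay compound 2 gives 1400 nM. The step of an at least 17-fold lower number from compound 1 to compound 2 (1.25 log units; beyond the scatter) is therefore large, though it rests on one limit of > 25000 nM in this assay, at which 1 of the 2 values shown sits, and one number. Among the compounds with values here, compound 2 is thus the only compound with a measured number; the other value is a limit.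

Compound 3 `Nc1nnc(SCc2coc3ccccc3c2=O)s1` differs from compound 2 by one change: 5-amino-1,3,4-thiadiazol-2-yl in place of 5-methyl-1,3,4-oxadiazol-2-yl on a sulfur. Within the data shown here, the only measured step, that from compound 1 to compound 2, bears on it in reverse: compound 1 also carries an amino group on its ring, and the return of an amino-bearing ring suggests a move back toward weaker inhibition, by an uncertain amount. For compound 3 the expected value in this assay is 6000 nM, with a range from 1500 nM to 25000 nM. That estimate means an expected step of a 4.3-fold higher number from compound 2 to compound 3 (0.63 log units; beyond the scatter).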

Compound 3, half-maximal inhibitory concentration: > 25000 nM
Compound 3: only a limit was reported (the forecaster's own chance of this, stated with the estimate: 30%); at least 4.1-fold (0.61 log units) between middle value and limit.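

Placing a 5-amino-1,3,4-thiadiazol-2-yl group on this sulfur in place of the 5-methyl-1,3,4-oxadiazol-2-yl group gives an at least 17-fold higher number from compound 2 to compound 3 (1.25 log units; beyond the scatter) in this assay, so a five-membered aromatic ring on the sulfur does not by itself secure the measured activity of compound 2. Among these three compounds, the two with an amino group on the ring, compound 1 and compound 3, both end at a limit rather than a number, and only the methyl-bearing ring of compound 2 gives a measured value: the limit of > 25000 nM in this assay, at which 2 of the 3 values shown sit. Both values for compound 1 and compound 3 are limits, so the step between them cannot be read.

This change replaces the ring oxygen with sulfur and the methyl group with an amino group at once, so the compounds shown cannot tell which of the two differences matters in this assay. A 5-methyl-1,3,4-thiadiazol-2-yl group or a 5-amino-1,3,4-oxadiazol-2-yl group on this sulfur would separate the two.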